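Removing the methylsulfonyl-bearing side group from compound 3

The source may report more compounds than this note shows. Statements on the series, on what has been measured and on what is new or still open speak of the compounds shown alone.

Measured compounds:
compound 1 `CCNC(=O)Nc1ccc(-c2nccc(C3=CCOCC3)n2)cc1`: 3.6
compound 2 `CC(C)(c1cc([C@]23CCOC[C@H]2C3)nc(-c2ccc(NC(=S)NCCO)cc2)n1)S(C)(=O)=O`: 3.9
compound 3 `CCNC(=O)Nc1ccc(-c2nc(C(C)(C)S(C)(=O)=O)cc([C@]34CCOC[C@H]3C4)n2)cc1`: 4.7

In a physicochemical assay for lipophilicity (on this read-out lower numbers stand for lower lipophilicity and higher numbers for higher lipophilicity), compound 3 stands highest of the three, with compound 2 nearest and compound 1 furthest below it. Going by the values given here, the only step that is counted, a number 0.80 log units higher from compound 2 to compound 3 (beyond the scatter), concerns the urea end of the molecule and not the place changed here. Compound 4 `CCNC(=O)Nc1ccc(-c2nccc([C@]34CCOC[C@H]3C4)n2)cc1` differs from compound 3 by hydrogen in place of 1-methyl-1-(methylsulfonyl)ethyl on an aromatic carbon. Among the compounds with values here, no measured pair shows this change, so the expectation leans on the values of compound 1 and compound 3, which lack the group or carry it. For compound 4 a step of a number 0.90 log units lower from compound 3 to compound 4 (beyond the scatter) is expected, downward. Compound 4 is therefore estimated at 3.8, within 3.2 to 4.4.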

Compound 4, partition coefficient: 3.9
Compound 4: the middle estimate sits 0.10 log units below what was measured; measured number inside the range.
By their numbers in this assay, from the lowest: compounds 1, 2 and 4 (each within the scatter of the next); then compound 3.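

Going by these compounds alone, replacing 1-methyl-1-(methylsulfonyl)ethyl with hydrogen on the aromatic carbon gives the first direct reading of this change in this assay (a number 0.80 log units lower from compound 3 to compound 4 (beyond the scatter)). The hydrogen-bearing compound also allows a comparison of the two groups of 7 and 6 heavy atoms on the other aromatic carbon (a number 0.30 log units higher from compound 1 to compound 4 (within the scatter)). No supporting data explain either step. The compounds shown leave open how an amine, a carboxylic acid or a longer chain on this aromatic carbon would compare with hydrogen. They also leave open whether this step would hold with another group at the urea end.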